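Replacing the Aryl Group on the Oxazolone Core

A few compounds are considered here, and "the series" means these few. Any claim that something is new, unique, unknown or untested is made for them only; others in the source may bear on it.

Compound 1 `O=c1[nH]cc(-c2ccccc2)o1` is reported in an assay on isolated protein for inhibition of acid ceramidase (Homo sapiens), read by LC-MS, with a stated time of 1 h (a higher number here means a weaker inhibitor, a lower number a stronger inhibitor), as "not active" (no number reported), with no number given. For the measured compounds named here, compound 2 `COc1ccccc1-c1cn(C(=O)NCCCCc2ccccc2)c(=O)o1` carries a carbamoyl chain on the ring nitrogen and an aryl group on the ring carbon, and in this assay compound 2 gives 177 nM, the only number in the set. Compound 3 `CN1CCC(c2cn(C(=O)NCCCCc3ccccc3)c(=O)o2)CC1` differs by 1-methylpiperidin-4-yl in place of 2-methoxyphenyl on an aromatic carbon. Going by the values given here, no measured pair tells how much this place matters, so the expected step is modest, toward weaker inhibition, as a 3.4-fold higher number from compound 2 to compound 3 (0.53 log units; beyond the scatter) for compound 3. Compound 3 is estimated at 600 nM, between 150 nM and 3000 nM.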

Compound 3, half-maximal inhibitory concentration: 1400 nM
Estimate against measurement, compound 3: 2.3-fold (0.37 log units) below; low and high end bracket the measured number.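

Changing 2-methoxyphenyl to 1-methylpiperidin-4-yl on this aromatic carbon next to the ring oxygen gives a 7.9-fold higher number from compound 2 to compound 3 (0.90 log units; beyond the scatter), so in this assay the group at this place clearly affects inhibition. The aromatic carbon ring is not essential for a measurable number, as compound 3 still gives 1400 nM. Nothing available here accounts for the weaker inhibition.

The compounds shown do not separate the loss of the aromatic ring from the entry of the ring nitrogen. A cyclohexyl group or an unsubstituted phenyl at this place would tell these two changes apart.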